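The source may hold more compounds than are shown below. What is called first, only, known or untested is meant among the compounds shown, and "the series" means these compounds.

Measured so far in a functional assay for inhibition, with Homo sapiens as the target; a higher number here means weaker binding, a lower number tighter binding:
- compound 1 `COc1ccc(OC(C)(C)C2OCC(C/C=C\CCC(=O)O)C(c3cccnc3)O2)cc1`: 302 nM
- compound 2 `CC(C)(Oc1ccc(F)cc1)C1OCC(C/C=C\CCC(=O)O)C(c2cccnc2)O1`: 120 nM
- compound 3 `COc1ccccc1OC(C)(C)C1OCC(C/C=C\CCC(=O)O)C(c2cccnc2)O1`: 224 nM

Compound 3 cannot be separated from either neighbour: the comparison with compound 1 gives a 1.3-fold lower number from compound 1 to compound 3 (0.13 log units; within the scatter), and the comparison with compound 2 gives a 1.9-fold higher number from compound 2 to compound 3 (0.27 log units; within the scatter). For the measured compounds named here, only the pair of compound 1 and compound 2 is separated, with a 2.5-fold lower number from compound 1 to compound 2 (0.40 log units; beyond the scatter).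

The next step leads to compound 4 `CC(C)(Oc1ccccc1[N+](=O)[O-])C1OCC(C/C=C\CCC(=O)O)C(c2cccnc2)O1`, a 2-nitrophenyl in place of the 2-methoxyphenyl of compound 3: nitro in place of methoxy on an aromatic carbon. Going by the values given here, no measured compound carries a nitro group, so no measured step matches this change directly. The nearest evidence is the replacement of methoxy by fluoro, a 2.5-fold lower number from compound 1 to compound 2 (0.40 log units; beyond the scatter), which is modest and sits on a 4-methoxyphenyl rather than a 2-methoxyphenyl. Moving the methoxy group gave only a 1.3-fold lower number from compound 1 to compound 3 (0.13 log units; within the scatter). On this evidence, a small step in this assay is expected, leaning weakly towards a lower number and probably not beyond the scatter.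

The estimated change is a 1.3-fold lower number from compound 3 to compound 4 (0.12 log units; within the scatter).

For compound 4 the expected value is 170 nM, with an estimated range of 70 nM to 400 nM.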

Compound 4, dissociation constant: 11.2 nM
Beside the measured number, compound 4's estimate is 15-fold (1.18 log units) above it; measured number below the stated range.
By their numbers in this assay, from the lowest: compound 4; then compounds 2, 3 and 1 (each within the scatter of the next, the first and the last beyond it).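

In this assay, for the compounds shown here, nitro in place of methoxy on an aromatic carbon, ortho to a large group, gives a 20-fold lower number from compound 3 to compound 4 (1.30 log units; beyond the scatter), the first large step in a series whose earlier steps were modest or within the scatter. The 2-nitrophenyl also stands clear of both other aryl groups on this oxygen, with an 11-fold lower number from compound 2 to compound 4 (1.03 log units; beyond the scatter) and a 27-fold lower number from compound 1 to compound 4 (1.43 log units; beyond the scatter), so this part of the molecule, which until now had moved the number little, can shift it strongly on a change of a single group. No measurement is available that bears on why the nitro group has this effect, and the step stands here as an observation only.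

Still open, from the compounds shown here alone, is whether another group on the same aromatic carbon, such as a nitrile, a trifluoromethyl or a carboxylic acid, gives a step of this size, or whether it stays with nitro alone. Also open, going by these compounds, is whether nitro keeps a step of this size on another carbon of the same ring, or whether it depends on the place printed for compound 4.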